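This account rests on a few compounds, and the source may have more. Where it says the series, first, only, none or still open, it means among the compounds named here.

Compound 1, `CC(C)c1onc(-c2c(Cl)cccc2Cl)c1COc1ccc(N(C)Cc2cccc(C(=O)O)c2)c(C(F)(F)F)n1`, and compound 2, `CC(c1ccc(OCc2c(-c3c(Cl)cccc3Cl)noc2C2CC2)nc1C(F)(F)F)N(C)c1ccc(C(=O)O)cc1`, were both examined in a functional assay on HEK293 cells for agonist activity at Bile acid receptor (Homo sapiens); a higher number here means a larger maximal response, a lower number a smaller maximal response. In this assay compound 1 gives 89%, while compound 2 gives 55%, the lowest of the two numbers; the gap between them lies beyond the usual scatter, with compound 1 standing higher. Compound 3, `CC(Oc1ccc(C(=O)O)cc1)c1ccc(OCc2c(-c3c(Cl)cccc3Cl)noc2C2CC2)nc1C(F)(F)F`, has not yet been measured in this assay. It differs from compound 2 in a single place: 4-carboxyphenoxy in place of (4-carboxyphenyl)(methyl)amino on a saturated chain carbon bound to an aromatic carbon and a saturated chain carbon. Going by the values given here, no pair of measured compounds shows this same change, so nothing measured tells how large a step it brings. The expected step is a number 5 percentage points higher from compound 2 to compound 3 (within the scatter), a small one that may well stay within the usual scatter, with no clear direction. The estimate for compound 3 in this assay is 60%, with a range from 35% to 85%.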

Compound 3, largest response reached (reported as efficacy), in percent of the reference or control that the assay uses: 70%
Compound 3: the middle estimate sits 10 percentage points below what was measured; the measured number falls inside the stated range.
By their numbers in this assay, from the lowest: compound 2; then compound 3; then compound 1.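

On the saturated chain carbon bound to an aromatic carbon and a saturated chain carbon, placing 4-carboxyphenoxy in place of (4-carboxyphenyl)(methyl)amino brings a number 15 percentage points higher from compound 2 to compound 3 (beyond the scatter) in this assay. Both groups carry a six-membered aromatic ring of carbon only and the same counts of hydrogen-bond donors and acceptors, so the maximal response at this position is not set by those shared features alone. No measurement available here accounts for the step.

The single exchange removes the methyl and replaces nitrogen with oxygen together, so the compounds shown leave open which of the two carries the step. A plain amino group without the methyl, or a sulfur atom in the place of the oxygen, would bear on that question.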